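Replacing a Methoxyphenyl Urea Group with Bromopyridyl

A few compounds are considered here, and "the series" means these few. Any claim that something is new, unique, unknown or untested is made for them only; others in the source may bear on it.

Measured compounds and their values in a functional assay on CHO cells for antagonist activity at C-X-C chemokine receptor type 3 (Homo sapiens), read by GTPgammaS binding; on this read-out higher numbers stand for weaker inhibition and lower numbers for stronger inhibition:
compound 1 `CC1(C)[C@H]2CC=C(CN3CCC(NC(=O)Nc4ccccc4)CC3)[C@@H]1C2` gives 2000 nM
compound 2 `CC(=O)c1cccc(NC(=O)NC2CCN(CC3=CC[C@H]4C[C@@H]3C4(C)C)CC2)c1` gives 258 nM
compound 3 `COc1cccc(NC(=O)NC2CCN(CC3=CC[C@H]4C[C@@H]3C4(C)C)CC2)c1` gives 429 nM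

Compound 3 stands second highest of these three numbers; its value and that of compound 2 lie within the scatter of each other (a 1.7-fold higher number from compound 2 to compound 3 (0.22 log units; within the scatter)), while the step of a 4.7-fold lower number from compound 1 to compound 3 (0.67 log units; beyond the scatter) is beyond it. Compound 4 `CC1(C)[C@H]2CC=C(CN3CCC(NC(=O)Nc4cncc(Br)c4)CC3)[C@@H]1C2` differs from compound 3 by 5-bromopyridin-3-yl in place of 3-methoxyphenyl on an amide-type nitrogen. Among the measured compounds shown here, no measured step makes this exact change. The steps of a 7.8-fold lower number from compound 1 to compound 2 (0.89 log units; beyond the scatter) and a 4.7-fold lower number from compound 1 to compound 3 (0.67 log units; beyond the scatter) only show that placing a group on the ring lowered the number modestly; the ring itself was never exchanged. The bromine keeps a ring substituent, so a step near zero, perhaps slightly upward, is expected: a 1.3-fold higher number from compound 3 to compound 4 (0.11 log units; within the scatter). Compound 4 is therefore estimated at 550 nM, between 150 nM and 2000 nM.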

Compound 4, inhibition constant: 171 nM
The estimate for compound 4 lay 3.2-fold (0.51 log units) above the measured number; the measured number falls inside the stated range.
By their numbers in this assay, from the lowest: compounds 4, 2 and 3 (each within the scatter of the next, the first and the last beyond it); then compound 1.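

The ring on this amide-type nitrogen need not be carbon only: in this assay, the exchange for 5-bromopyridin-3-yl gives a 2.5-fold lower number from compound 3 to compound 4 (0.40 log units; beyond the scatter). Against 3-acetylphenyl the new group cannot be told apart, with a 1.5-fold lower number from compound 2 to compound 4 (0.18 log units; within the scatter), while the step from plain phenyl is large, a 12-fold lower number from compound 1 to compound 4 (1.07 log units; beyond the scatter). No measurement here explains these steps.

Going by these compounds, what the ring nitrogen and the bromine each contribute stays open. Plain pyridin-3-yl and 3-bromophenyl would separate the two, and a chlorine in place of the bromine would test the halogen.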